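Clearance notes: the step to compound 3

The source may report more compounds than this note shows. Statements on the series, on what has been measured and on what is new or still open speak of the compounds shown alone.

- compound 1 `Cc1ccc(NC(=O)c2cc(Oc3ccc(S(C)(=O)=O)cc3)cc(OC(C)C)c2)nc1`: 17 mL/min/kg
- compound 2 `CC(C)Oc1cc(Oc2ccc(S(C)(=O)=O)cc2)cc(-c2cccc(=O)[nH]2)c1`: < 8 mL/min/kg (a limit)

Both values come from an ADME assay on microsomes from liver (Homo sapiens) for metabolic stability; on this read-out lower numbers stand for slow clearance and higher numbers for fast clearance. Compound 2 stands at < 8 mL/min/kg, which is a limit of the assay and not a number.

Compound 3 `CC(C)Oc1cc(Oc2ccc(S(C)(=O)=O)cc2)cc(-c2cncc(=O)[nH]2)c1` keeps the shared core and changes one group: a group of 7 heavy atoms (4 carbon, 2 nitrogen, 1 oxygen; one six-membered aromatic ring with 2 hetero atoms) in place of a group of 7 heavy atoms (5 carbon, 1 nitrogen, 1 oxygen; one six-membered aromatic ring with 1 hetero atom), on an aromatic carbon. The group on the aromatic carbon keeps its 7 heavy atoms, but its six-membered aromatic ring now has 2 hetero atoms.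

For the measured compounds named here, only one measured step bears on this: an at least 2.1-fold lower number from compound 1 to compound 2 (0.32 log units; beyond the scatter). It also exchanged a group on an aromatic carbon, but a different group, so it is only a loose guide. On that thin basis, no step beyond the scatter is expected in this assay, and the estimated step is a step that the limit leaves unreadable from compound 2 to compound 3. For compound 3 the expected clearance is 6 mL/min/kg, with an estimated range of 3 mL/min/kg to 12 mL/min/kg.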

Compound 3, clearance in the Homo sapiens assay: 11 mL/min/kg
Compound 3: the middle estimate sits 1.8-fold (0.26 log units) below what was measured, and the stated range covers the measured number.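

Compound 2 stands in the Homo sapiens assay at < 8 mL/min/kg, which is a limit of the assay and not a number. In the Homo sapiens assay, the ring with 2 hetero atoms at this aromatic carbon gives an at least 1.3-fold higher number from compound 2 to compound 3 (0.13 log units; that floor lies within the scatter), and against the group of 10 heavy atoms it gives a 1.5-fold lower number from compound 1 to compound 3 (0.19 log units; within the scatter), so the clear step seen with the earlier exchange at this position does not hold for every group of 7 heavy atoms. In a physicochemical assay for lipophilicity, using the shake flask method (a higher number here means a more lipophilic compound, a lower number a more polar compound), compound 2 gives 2.82, and compound 3 gives 2.27. In the physicochemical assay the same exchange gives a number 0.55 log units lower from compound 2 to compound 3 (beyond the scatter), and no matching fall in clearance can be read alongside it.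

From the compounds shown here alone, the true size of the clearance step remains open while one of its ends is a limit. Also open, going by these compounds, is how an amine or a carboxylic acid on this aromatic carbon would behave in the Homo sapiens assay.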